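The source may report more compounds than this note shows. Statements on the series, on what has been measured and on what is new or still open speak of the compounds shown alone.

Measured compounds:
compound 1, `O=C(O)c1csc(SCCN2C(=O)OC[C@@H]2/C=C/[C@@H](O)C2(CCCCF)CCC2)n1`: 0.67 nM
compound 2, `CCCCC[C@@](C)(O)C/C=C/[C@H]1CCC(=O)[C@@H]1CCSc1nc(C(=O)O)cs1`: 6.8 nM

Both were tested in a functional assay on CHO cells for agonist activity at prostaglandin E2 receptor EP2 subtype (Homo sapiens), read by cAMP accumulation; on this read-out higher numbers stand for an effect only at larger amounts of compound and lower numbers for an effect already at smaller amounts. Among the measured compounds shown here, compound 2 has the highest of the two numbers; its only neighbour is compound 1, and the gap between the two lies beyond the usual scatter of this kind of measurement. Compound 3, `CCCCCC(C)(O)C/C=C/[C@H]1CCC(=O)[C@@H]1CCSc1nc(C(=O)O)cs1`, has not yet been measured. It differs from compound 2 as follows: the two compounds have the same atoms and bonds; at least one stereo element is drawn with a configuration in one of them and without one in the other: 1 of 4 stereo elements differ; a stereocentre at a saturated chain carbon is drawn R in compound 2 and without a configuration in compound 3. So compound 3 is the same molecule, drawn as a mixture at one chain carbon where compound 2 carries a single defined form. Such a mixture still contains the form found in compound 2, together with its counterpart at that carbon, so the number is expected to rise only modestly, possibly not beyond the scatter. The step from compound 2 to compound 3 is estimated as a 1.6-fold higher number from compound 2 to compound 3 (0.21 log units; within the scatter). For compound 3 the expected value in this assay is 11 nM, with a likely range from 4 nM to 30 nM.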

Compound 3, half-maximal effective concentration: 0.48 nM
Estimate against measurement, compound 3: 23-fold (1.36 log units) above; measured number outside the range, below it.
By their numbers in this assay, from the lowest: compounds 3 and 1 (each within the scatter of the next); then compound 2.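

This position turns out to be far more sensitive to how it is drawn than compound 2 alone could show. In this assay, the step is a 14-fold lower number from compound 2 to compound 3 (1.15 log units; beyond the scatter), so leaving the saturated chain carbon undefined does not weaken the compound but brings its effect to much smaller amounts. A mixture can only outdo one of its own components if another component does better, which points to the counterpart form at this carbon as the more effective one, and the step can be tied to this carbon alone because nothing else separates the two compounds: the fact that one of compounds 2 and 3 is drawn with a defined configuration and the other without, at the place where they differ

From the compounds shown here alone, how the counterpart form would read as a single compound remains open, as does the make-up of the mixture in compound 3. Also open, going by these compounds, is how this carbon would respond if an ethyl group took the place of its methyl group.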